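Cinnamamide series: pyrazinylmethoxy on the styryl ring, cytotoxicity

The source may report more compounds than this note shows. Statements on the series, on what has been measured and on what is new or still open speak of the compounds shown alone.

Within the data shown here, in a functional assay on SH-SY5Y cells (Homo sapiens) for cytotoxicity, read by MTT assay, with stated times of 24 h and 4 h (a lower number here means that less compound is needed, a higher number that more compound is needed for the effect), compound 1 `COc1cc(CNC(=O)/C=C/c2ccccc2)ccc1OCc1nc(C)c(C)nc1C` gives 7310 nM, the highest of the three numbers so far. Compound 2 `COc1cc(CNC(=O)/C=C/c2ccccc2O)ccc1OCc1nc(C)c(C)nc1C` gives 5300 nM and compound 3 `COc1cc(CNC(=O)/C=C/c2ccccc2OCc2nc(C)c(C)nc2C)ccc1OCc1nc(C)c(C)nc1C` gives 6280 nM, both within the scatter of compound 1. Compound 4 `COc1cc(CNC(=O)/C=C/c2cccc(OCc3nc(C)c(C)nc3C)c2)ccc1OCc1nc(C)c(C)nc1C` differs from compound 1 by (3,5,6-trimethylpyrazin-2-yl)methoxy in place of hydrogen on an aromatic carbon. Among the measured compounds shown here, the nearest precedent is the addition of the same group elsewhere on that ring, a 1.2-fold lower number from compound 1 to compound 3 (0.07 log units; within the scatter); the related steps of a 1.4-fold lower number from compound 1 to compound 2 (0.14 log units; within the scatter) and a 1.2-fold higher number from compound 2 to compound 3 (0.07 log units; within the scatter) are likewise within the scatter. No step beyond the scatter is therefore expected in this assay, a 1.1-fold lower number from compound 1 to compound 4 (0.05 log units; within the scatter). Compound 4 is estimated at 6500 nM, with a range of 3000 nM to 14000 nM.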

Compound 4, half-maximal effective concentration: 8700 nM
Compound 4: the middle estimate sits 1.3-fold (0.13 log units) below what was measured; low and high end bracket the measured number.
By their numbers in this assay, from the lowest: compounds 2, 3, 1 and 4 (each within the scatter of the next).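

In this assay, (3,5,6-trimethylpyrazin-2-yl)methoxy on the aromatic carbon meta to a large group gives a 1.2-fold higher number from compound 1 to compound 4 (0.08 log units; within the scatter). This position therefore takes a group of this size without a step beyond the scatter, as the other placement on that ring in compound 3 did. No measurement available here explains this result.

On these data alone, whether any substituent at this position can move the number beyond the scatter stays open. An amine or a carboxylic acid here would test that.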